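A few compounds are considered here, and "the series" means these few. Any claim that something is new, unique, unknown or untested is made for them only; others in the source may bear on it.

Compound 2 `CCOc1ccc(C(=O)/C=C/c2ccc(C(=O)Nc3cccc(-c4cc(C(=O)OC)no4)c3)cc2)cc1` is one of two close relatives measured in an ADME assay on Vero cells (Chlorocebus sabaeus) for cytotoxicity, read by MTT assay, with a stated time of 72 h; a higher number here means that more compound is tolerated, a lower number that less compound is tolerated. In this assay compound 2 gives > 40 ug/mL, which is a limit of the assay rather than a number. Its relative, compound 1 `COC(=O)c1cc(-c2cccc(NC(=O)c3ccc(/C=C/C(=O)c4ccc(C)cc4)cc3)c2)on1`, differs from it by an ethoxy in place of a methyl on an aromatic carbon. In this assay compound 1 gives > 80 ug/mL, again a limit of the assay rather than a number. The step that the two limits leave unreadable from compound 1 to compound 2 cannot be given a size because its two ends are the limits the limit of > 80 ug/mL in this assay, at which 1 of the 2 values shown sits, and (the limit of > 40 ug/mL in this assay, at which 1 of the 2 values shown sits).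

Compound 3 `COC(=O)c1cc(-c2cccc(NC(=O)c3ccc(/C=C/C(=O)c4ccccc4C)cc3)c2)on1` has not yet been measured in this assay. It differs from compound 2 by 2-methylphenyl in place of 4-ethoxyphenyl on a carbonyl carbon. Going by the values given here, the only measured step, from compound 1 to compound 2, is unreadable, so no measured step bears directly on this change. With both relatives sitting at limits, the step that the limit leaves unreadable from compound 2 to compound 3 is expected to remain within the scatter, most likely again as a limit. For compound 3 the estimate in this assay is 60 ug/mL, within a range of 30 ug/mL to 120 ug/mL.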

Compound 3, half-maximal cytotoxic concentration: > 25 ug/mL
Compound 3 was reported as a limit (the forecaster's own chance of this, stated with the estimate: 75%); the middle value lies beyond the limit too.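

In this assay, going by these compounds alone, compound 1, compound 2 and compound 3 are all reported only as limits of the assay, so no step among them can be read. The compounds shown leave open the concentration at which each stops being tolerated, and whether 2-methylphenyl in place of 4-ethoxyphenyl changes that concentration at all.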